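A few compounds are considered here, and "the series" means these few. Any claim that something is new, unique, unknown or untested is made for them only; others in the source may bear on it.

Compound 1 `O=C(NO)c1ccc(NCc2nc(-c3cccnc3)nn2-c2ccccc2)cc1` is a hydroxamic acid tested in an assay on Sf9 cells for inhibition of protein deacetylase HDAC6 (Homo sapiens), read by fluorescence, with a stated time of 40 min, tested at 100 nM (on this read-out higher numbers stand for more inhibition at the one concentration tested (going by the name of the read-out) and lower numbers for less inhibition), where compound 1 gives 57.7%. Among the three compounds measured so far this is the second highest number. Compound 2 `Cc1cccc(-n2nc(-c3ccccc3)nc2CNc2ccc(C(=O)NO)cc2)c1` gives 66%, a gap from compound 1 that lies within the usual scatter of the measurement, so the two cannot be ranked. Compound 3 `NNC(=O)c1ccc(NCc2nc(-c3ccccc3)nn2-c2ccccc2)cc1`, which carries a hydrazide instead of the hydroxamic acid, gives 10%, a gap from compound 1 that lies beyond the scatter.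

Compound 4 `O=C(NO)c1ccc(NCc2nc(-c3ccccn3)nn2-c2ccccc2)cc1` has not yet been measured. It differs from compound 1 in one place: pyridin-2-yl in place of pyridin-3-yl on an aromatic carbon. Going by the values given here, no pair of measured compounds shows the effect of such a change, so the size of the expected step is uncertain. The expected step is about a number 5.7 percentage points lower from compound 1 to compound 4 (within the scatter). Compound 4 is estimated to give 52%, with a range from 30% to 72%.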

Compound 4, a percentage reported as inhibition, at one concentration (the size of the read-out at that concentration, not a potency): 58.6%
Compound 4: middle estimate off by 6.6 percentage points, on the low side; the range from low to high includes it.
By their numbers in this assay, from the lowest: compound 3; then compounds 1, 4 and 2 (each within the scatter of the next).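

In this assay, pyridin-2-yl in place of pyridin-3-yl on this aromatic carbon gives a number 0.9 percentage points higher from compound 1 to compound 4 (within the scatter). Going by these compounds alone, at this one concentration, then, the two pyridine attachments cannot be told apart, which the earlier compounds could not show. No measurement at hand offers an explanation for this result. Still open, from the compounds shown here alone, is how pyridin-4-yl, or a small group such as an amine or a carboxylic acid, would read on the same carbon. A single concentration also leaves open whether compound 1 and compound 4 would match in a full potency measurement.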